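A few compounds are considered here, and "the series" means these few. Any claim that something is new, unique, unknown or untested is made for them only; others in the source may bear on it.

Compound 1, `Cc1ccc(-c2cc(C(=O)N3CCC4(CC3)CC(=O)c3nn(C(C)(C)C)cc3O4)c3ccccc3n2)cc1`, in a functional assay on MDA-MB-231 cells (Homo sapiens) for inhibition, read by MTT assay, with a stated time of 72 h (on this read-out higher numbers stand for weaker inhibition and lower numbers for stronger inhibition), gives > 10000 nM, which is a limit of the assay and not a number.
Compound 2, `Cc1ccccc1-c1cc(C(=O)N2CCC3(CC2)CC(=O)c2nn(C(C)(C)C)cc2O3)c2ccccc2n1`, in this assay gives > 10000 nM, again a limit of the assay.
Compound 3, `COc1ccc(-c2cc(C(=O)N3CCC4(CC3)CC(=O)c3nn(C(C)(C)C)cc3O4)c3ccccc3n2)cc1`, in this assay gives > 10000 nM, also a limit of the assay.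

Compound 3 thus stands at the same limit as the other two measured compounds: the limit of > 10000 nM in this assay, at which 3 of the 3 values shown sit. Each of the three steps between them is therefore unreadable: a step that the two limits leave unreadable from compound 1 to compound 2, a step that the two limits leave unreadable from compound 1 to compound 3 and a step that the two limits leave unreadable from compound 2 to compound 3. None of them tells how much a change on the shared core moves the result.

Compound 4, `CCOc1cc(C(=O)N2CCC3(CC2)CC(=O)c2nn(C(C)(C)C)cc2O3)c2ccccc2n1`, differs from compound 3 in one place: ethoxy in place of 4-methoxyphenyl on an aromatic carbon. Among the compounds with values here, no measured step bears directly on this change, and the three steps that exist give no size and no direction. Nothing in the measurements points up or down. Compound 4 is therefore expected to sit near 15000 nM, in a range from 3000 nM to 60000 nM, most probably reported again as a limit rather than a number. This expectation corresponds to a step that the limit leaves unreadable from compound 3 to compound 4.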

Compound 4, half-maximal inhibitory concentration: > 10000 nM
Compound 4: only a limit was reported; the forecaster's own chance of this, stated with the estimate: 75%; the middle value is on the limit's open side.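

Compound 4 gives > 10000 nM, again a limit of the assay and not a number. No step from compound 1, compound 2 or compound 3 to compound 4 can be read, because all four share one limit: the limit of > 10000 nM in this assay, at which 4 of the 4 values shown sit.

Still open, from the compounds shown here alone, is whether any change on the shared core brings a measurable value in this assay.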